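Swapping the Amine-Bearing Ring at the Amide End

A few compounds are considered here, and "the series" means these few. Any claim that something is new, unique, unknown or untested is made for them only; others in the source may bear on it.

Compound 3 `CCN(CC)C1CCN(C(=O)CCCOc2cc(C(=O)N3CCCCc4sccc43)ccc2NC(=O)c2ccccc2-c2ccccc2)CC1` gives 6 nM in an assay on adrenal medulla for inhibition of Vasopressin V2 receptor (Rattus norvegicus), read by radioligand binding; a lower number here means a stronger inhibitor, a higher number a weaker inhibitor. Among the three measured compounds it stands second highest: compound 1 `CN(C)C1CCN(C(=O)CCCOc2cc(C(=O)N3CCCCc4sccc43)ccc2NC(=O)c2ccccc2-c2ccccc2)CC1` gives 3 nM, a difference a 2.0-fold higher number from compound 1 to compound 3 (0.30 log units; within the scatter), while compound 2 `O=C(Nc1ccc(C(=O)N2CCCCc3sccc32)cc1OCCCC(=O)N1CCC(N2CCCCC2)CC1)c1ccccc1-c1ccccc1` gives 20 nM, a step of a 3.3-fold lower number from compound 2 to compound 3 (0.52 log units; beyond the scatter). Compound 4 `CN1CCCN(C(=O)CCCOc2cc(C(=O)N3CCCCc4sccc43)ccc2NC(=O)c2ccccc2-c2ccccc2)CC1` carries 4-methyl-1,4-diazepan-1-yl in place of 4-(diethylamino)piperidin-1-yl on a carbonyl carbon. All three measured steps change the amine at this same end of the molecule, and none moved this assay far; the largest was a 6.7-fold higher number from compound 1 to compound 2 (0.82 log units; beyond the scatter). Since a ring-bound amine returns here in a different ring, a modest step is expected, a 1.7-fold higher number from compound 3 to compound 4 (0.22 log units; within the scatter), in either direction. Compound 4 is therefore estimated at 10 nM, between 3 nM and 40 nM.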

Compound 4, half-maximal inhibitory concentration: 3 nM
Estimate against measurement, compound 4: 3.3-fold (0.52 log units) above, and the stated range covers the measured number.
By their numbers in this assay, from the lowest: compounds 1, 4 and 3 (each within the scatter of the next); then compound 2.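

The 4-methyl-1,4-diazepan-1-yl group, with one seven-membered non-aromatic ring holding 2 hetero atoms, can stand on this carbonyl carbon in place of the 4-(diethylamino)piperidin-1-yl group without a change beyond the scatter in this assay (a 2.0-fold lower number from compound 3 to compound 4 (0.30 log units; within the scatter)). The same holds against the 4-(dimethylamino)piperidin-1-yl group (no change at the digits printed from compound 1 to compound 4 (within the scatter)), while the step from the 4-(piperidin-1-yl)piperidin-1-yl group is larger (a 6.7-fold lower number from compound 2 to compound 4 (0.82 log units; beyond the scatter)). So among these compounds, the amine need not sit on a six-membered ring.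

Going by these compounds, whether morpholin-4-yl or an open-chain amine such as 2-(dimethylamino)ethylamino would fit here remains open. Nothing shown explains these numbers.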